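Compound 2 to compound 4: methoxy replaces cyano

The source may report more compounds than this note shows. Statements on the series, on what has been measured and on what is new or still open speak of the compounds shown alone.

In an ADME assay on the whole organism (Rattus norvegicus) for pharmacokinetics, read by HPLC, at a dose of 3 mg/kg by the oral route (on this read-out lower numbers stand for lower exposure and higher numbers for higher exposure at the dose given), three compounds sharing one core have been measured: compound 1 `N#Cc1cc(C(=O)N2CS(=O)(=O)c3ccccc32)cc(C2CC2)c1O` gives 10800 nM, compound 3 `CCc1cc(C(=O)N2CS(=O)(=O)c3ccccc32)cc(C#N)c1O` gives 12400 nM and compound 2 `N#Cc1cc(C(=O)N2CS(=O)(=O)c3ccccc32)cc(Cl)c1O` gives 3870 nM, the lowest of the three. Compound 4 `COc1cc(C(=O)N2CS(=O)(=O)c3ccccc32)cc(Cl)c1O` carries methoxy in place of cyano on an aromatic carbon, ortho to a hydroxy group: methoxy in place of cyano on an aromatic carbon. Going by the values given here, no measured step touches the cyano group. Among the compounds with values here, the only guides change the other substituent: a 2.8-fold lower number from compound 1 to compound 2 (0.45 log units; beyond the scatter), a 3.2-fold higher number from compound 2 to compound 3 (0.51 log units; beyond the scatter) and a 1.1-fold higher number from compound 1 to compound 3 (0.06 log units; within the scatter). These are modest or smaller, so in this assay a small downward move, not clearly beyond the scatter, is expected. The estimated step is a 1.8-fold lower number from compound 2 to compound 4 (0.25 log units; within the scatter). The expected value for compound 4 is 2200 nM, with an estimated range of 700 nM to 6500 nM.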

Compound 4, maximal plasma concentration: 3000 nM
Compound 4: the middle estimate sits 1.4-fold (0.13 log units) below what was measured, within the range that was stated.
By their numbers in this assay, from the lowest: compounds 4 and 2 (each within the scatter of the next); then compounds 1 and 3 (each within the scatter of the next).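

In this assay, the change ortho to a hydroxy group gives a 1.3-fold lower number from compound 2 to compound 4 (0.11 log units; within the scatter), so with chloro held in place, cyano and methoxy cannot be told apart on this read-out. The earlier compounds shown here varied only the other substituent, where a 2.8-fold lower number from compound 1 to compound 2 (0.45 log units; beyond the scatter) and a 3.2-fold higher number from compound 2 to compound 3 (0.51 log units; beyond the scatter) both lay beyond the scatter; this single change at the new position does not. Nothing available bears on the reason for this result.

Going by these compounds, whether methoxy would behave the same way alongside cyclopropyl or ethyl remains open. So does the effect of an amine or a carboxylic acid at this position.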